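The source may hold more compounds than are shown below. What is called first, only, known or untested is meant among the compounds shown, and "the series" means these compounds.

Compound 1, `CCOc1ccccc1Nc1nc2nonc2nc1Nc1ccccc1F`: 5600 nM
Compound 2, `CCOc1cccc(Nc2nc3nonc3nc2Nc2ccccc2F)c1`: 2200 nM
Compound 3, `Fc1ccccc1Nc1nc2nonc2nc1Nc1ccccc1OC(F)(F)F`: 1700 nM

The three compounds were measured in an assay on mitochondria from L6 cells (Rattus norvegicus) for activation, with a stated time of 90 min; a higher number here means that more compound is needed for the effect, a lower number that less compound is needed. Compound 1 differs from compound 2 in that the two share the same atoms joined differently: 3-ethoxyphenyl in place of 2-ethoxyphenyl on a nitrogen on an aromatic ring. That change gives a 2.5-fold lower number from compound 1 to compound 2 (0.41 log units; beyond the scatter). Compound 3 differs from compound 1 by trifluoromethyl in place of ethyl on an oxygen on an aromatic ring, and that change gives a 3.3-fold lower number from compound 1 to compound 3 (0.52 log units; beyond the scatter). Compound 2 and compound 3 lie within the usual scatter of each other, so no order between them is claimed.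

Compound 4, `Fc1ccccc1Nc1nc2nonc2nc1Nc1cccc(OC(F)(F)F)c1`, has not yet been measured in this assay . It differs from compound 2 by trifluoromethyl in place of ethyl on an oxygen on an aromatic ring. The place of this change is described in the same words as the change from compound 1 to compound 3, so it is the same change made on the core of compound 2. Because the earlier step was a 3.3-fold lower number from compound 1 to compound 3 (0.52 log units; beyond the scatter), the step from compound 2 to compound 4 is expected to be of a similar size, a 2.8-fold lower number from compound 2 to compound 4 (0.44 log units; beyond the scatter). Compound 4 is therefore estimated at 800 nM, with a likely range from 300 nM to 2200 nM, resting on a single prior example of the change.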

Compound 4, half-maximal effective concentration: 600 nM
Estimate against measurement, compound 4: 1.3-fold (0.12 log units) above; the measured number falls inside the stated range.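

In this assay, trifluoromethyl in place of ethyl on the oxygen gives a 3.7-fold lower number from compound 2 to compound 4 (0.56 log units; beyond the scatter), so less compound is needed for the effect after the change. Set beside the earlier step, the change carries over between the two cores with no difference in size beyond the scatter: the same change on two cores in this assay, a 3.3-fold lower number (0.52 log units; beyond the scatter) from compound 1 to compound 3 and a 3.7-fold lower number (0.56 log units; beyond the scatter) from compound 2 to compound 4, 1.1-fold (0.05 log units) apart, within the scatter of two such steps. For the compounds shown here, this shows that the step keeps its direction and size on both the 2-ethoxyphenyl and the 3-ethoxyphenyl series, but it rests on only two pairs in one assay and does not show that it would hold on any further core, nor does it explain why the number falls.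

The compounds shown carry only ethyl or trifluoromethyl on that oxygen, so it stays open how a longer chain such as propyl, a plain methyl or an amine in that place would compare. The fluorine on the other aromatic ring is also shared by all four compounds, which leaves open whether the step survives when a chlorine or a methyl stands in its place.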